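A few compounds are considered here, and "the series" means these few. Any claim that something is new, unique, unknown or untested is made for them only; others in the source may bear on it.

Compound 1 `O=C(CCCCCNc1c(NCc2ccccc2)c(=O)c1=O)NO` and compound 2 `C[C@@H](Nc1c(NCCCCCC(=O)NO)c(=O)c1=O)c1ccccc1` share a core; compound 3 `CC(CCCCC(=O)NO)Nc1c(Nc2ccc(C(F)(F)F)cc2)c(=O)c1=O` and compound 4 `CC(C)(CCCCC(=O)NO)Nc1c(Nc2ccc(C(F)(F)F)cc2)c(=O)c1=O` share another, and the difference between the two cores is not broken down here. In a physicochemical assay for solubility, with a stated time of 24 h, tested at 30 mg/mL (on this read-out higher numbers stand for higher solubility and lower numbers for lower solubility), compound 1 gives 5700000 nM; compound 2 gives 39000000 nM; compound 3 gives 20000000 nM. Among the compounds with values here, the one measured step is a 6.8-fold higher number from compound 1 to compound 2 (0.84 log units; beyond the scatter), the change being (methyl in place of hydrogen on a saturated chain carbon bound to an aromatic carbon and a nitrogen on an aromatic ring). The change from compound 3 to compound 4 is methyl in place of hydrogen on a saturated chain carbon bound to a nitrogen on an aromatic ring and two saturated chain carbons, the same kind of change but not the same: in compound 1 the carbon is bound to an aromatic carbon and a nitrogen on an aromatic ring, in compound 3 to a nitrogen on an aromatic ring and two saturated chain carbons. Within the data shown here, with a single step on another core as the only guide, a smaller increase is expected for compound 4, a 1.8-fold higher number from compound 3 to compound 4 (0.24 log units; within the scatter). The estimate for compound 4 in this assay is 35000000 nM.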

Compound 4, solubility: 30000000 nM
Estimate against measurement, compound 4: 1.2-fold (0.07 log units) above; the measured number falls inside the stated range.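

In this assay, methyl in place of hydrogen gives a 1.5-fold higher number from compound 3 to compound 4 (0.18 log units; within the scatter) on this core, whereas on the core of compound 1 the related change gives a 6.8-fold higher number from compound 1 to compound 2 (0.84 log units; beyond the scatter) on a different kind of carbon. A step beyond the scatter on one core therefore did not carry over as one on the other, and the change on the saturated chain carbon bound to a nitrogen on an aromatic ring and two saturated chain carbons cannot be told apart from repeat variation. With one pair per core, this does not show whether the core or the kind of carbon decides the outcome, and nothing available bears on the reason.

Open, going by these compounds, is how an ethyl group or an amine on this same carbon would read in this assay. Also open, on these data alone, is whether a carboxylic acid in place of the hydroxamic acid end of the chain would leave the methyl step unchanged on either core.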